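This account rests on a few compounds, and the source may have more. Where it says the series, first, only, none or still open, it means among the compounds named here.

Measured compounds in an assay on isolated protein for inhibition of myosin-2 (Bos taurus), read by spectrophotometry, with a stated time of 24 min; a higher number here means a weaker inhibitor, a lower number a stronger inhibitor:
compound 1 `C/C(=N\CCO)c1c(O)c2ccccc2oc1=O` gives 92000 nM
compound 2 `CCC/N=C(\C)c1c(O)c2ccccc2[nH]c1=O` gives >= 100000 nM, a limit of this assay rather than a number
compound 3 `C/C(=N\Cc1cccc(C)c1)c1c(O)c2ccccc2oc1=O` gives 4900 nM

Compound 3 holds the lowest of the two actual numbers in this assay; the nearest is compound 1, and the step of a 19-fold lower number from compound 1 to compound 3 (1.27 log units; beyond the scatter) separates them. The third value, that of compound 2, is only a limit, see (the limit of >= 100000 nM in this assay, at which 1 of the 3 values shown sits), and sets no number against compound 3.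

Compound 4 `C/C(=N\Cc1ccccc1C)c1c(O)c2ccccc2oc1=O` is still to be measured in this assay. It differs from compound 3 in one place: 2-methylphenyl in place of 3-methylphenyl on a saturated chain carbon bound to a double-bonded nitrogen. The two have the same atoms, joined differently. Among the measured compounds shown here, the only measured step, a 19-fold lower number from compound 1 to compound 3 (1.27 log units; beyond the scatter), concerns a different change, the exchange of hydroxymethyl for 3-methylphenyl, and says nothing direct about moving the methyl within the phenyl ring. For the measured compounds named here, no measured pair shows such a change, so there is nothing to point to a step beyond the scatter in either direction.

Accordingly, the number for compound 4 is expected to stay close to that of compound 3, with the step of a 1.1-fold higher number from compound 3 to compound 4 (0.05 log units; within the scatter) estimated to lie within the scatter. The estimate for compound 4 in this assay is 5500 nM, with a range from 1800 nM to 17000 nM.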

Compound 4, half-maximal inhibitory concentration: >= 100000 nM
Compound 4 ended at the assay's limit; the forecaster's own chance of this, stated with the estimate: 5%; at least 18-fold (1.25 log units) between middle value and limit.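

In this assay compound 4 gives >= 100000 nM, a limit of this assay and not a number. Moving the methyl, with the same atoms joined differently, gives an at least 20-fold higher number from compound 3 to compound 4 (1.30 log units; beyond the scatter), so the gain in a 19-fold lower number from compound 1 to compound 3 (1.27 log units; beyond the scatter) does not come from just any methylphenyl group on the saturated chain carbon bound to the double-bonded nitrogen, but depends on where the methyl sits on the phenyl ring. Against the hydroxymethyl group the reading is an at least 1.0-fold higher number from compound 1 to compound 4 (0.03 log units; that floor lies within the scatter), so 2-methylphenyl cannot be set apart from hydroxymethyl at this place, and of the two methylphenyl groups shown only 3-methylphenyl gives a number well clear of the limit.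

Going by these compounds, how far compound 4 lies beyond what this assay can report stays open, so the step from 3-methylphenyl to 2-methylphenyl has a floor but no size: the limit of >= 100000 nM in this assay, at which 2 of the 4 values shown sit. Also open, on these data alone, is how a plain phenyl group, or a methoxy group, an amine or a longer chain in place of the methyl, would read at this place in this assay.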